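The source may report more compounds than this note shows. Statements on the series, on what has been measured and on what is new or still open speak of the compounds shown alone.

Measured in a physicochemical assay for solubility, read by chemiluminescence, measured as kinetic solubility; a lower number here means a less soluble compound, a higher number a more soluble compound:
- Compound 1 `COc1nn(C(C)C)c2ncnc(NS(=O)(=O)c3cccc(Cl)c3Cl)c12`: 404000 nM
- Compound 2 `CNC(=O)Cn1nc(OC)c2c(NS(=O)(=O)c3cccc(Cl)c3Cl)ncnc21`: >= 509000 nM, a limit of the assay

Compound 2 has no number of its own, only a limit, so its place in the series is open upward: the limit of >= 509000 nM in this assay, at which 1 of the 2 values shown sits.

Compound 3 `COc1nn(CCN(C)C)c2ncnc(NS(=O)(=O)c3cccc(Cl)c3Cl)c12` has (dimethylamino)methyl in place of methylcarbamoyl on a saturated chain carbon bound to an aromatic nitrogen. The same substituent, cut one bond further out, reads as (methylcarbamoyl)methyl to 2-(dimethylamino)ethyl.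

Within the data shown here, only one measured step bears on this change: an at least 1.2-fold higher number from compound 1 to compound 2 (0.10 log units; that floor lies within the scatter). It also concerns the group on the aromatic nitrogen, and it gives a floor rather than a size. No move beyond the scatter is therefore expected in this assay, in either direction.

The expected change is an at least 1.1-fold lower number from compound 2 to compound 3 (0.05 log units; that floor lies within the scatter).

For compound 3 the estimate is 450000 nM, with an expected range of 220000 nM to 620000 nM.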

Compound 3, solubility: 358000 nM
For compound 3 the middle estimate is 1.3-fold (0.10 log units) above the measured one, and the stated range covers the measured number.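

In this assay, among these compounds, the first direct comparison of 2-(dimethylamino)ethyl with isopropyl on the aromatic nitrogen reads a 1.1-fold lower number from compound 1 to compound 3 (0.05 log units; within the scatter), so these two groups are not told apart here. Against (methylcarbamoyl)methyl the reading is an at least 1.4-fold lower number from compound 2 to compound 3 (0.15 log units; that floor lies within the scatter), which gives a floor and leaves the true size of this change unknown. Compound 2 has a limit of the assay and not a number: the limit of >= 509000 nM in this assay, at which 1 of the 3 values shown sits.

So far, no step at this position is shown to lie beyond the scatter, and how far (methylcarbamoyl)methyl truly stands from the other two groups stays open. On these data alone, how a carboxylic acid, a cyclic amine or a longer chain on the aromatic nitrogen would read in this assay also remains open.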